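The source may report more compounds than this note shows. Statements on the series, on what has been measured and on what is new or still open speak of the compounds shown alone.

Three compounds stand level in a functional assay on HL-60 cells (Homo sapiens) for antiproliferative activity, read by MTT assay, with a stated time of 72 h; a higher number here means a weaker inhibitor, a lower number a stronger inhibitor: compound 1 `CCn1cc(C(=O)O)c(=O)c2cc(F)c(N3CCN(C(=N)NS(=O)(=O)c4ccc(C(F)(F)F)cc4)CC3)cc21` gives 43 nM, compound 2 `N=C(NS(=O)(=O)c1ccc(Cl)cc1)N1CCN(c2cc3c(cc2F)c(=O)c(C(=O)O)cn3C2CC2)CC1` gives 43 nM, and compound 3 `CCn1cc(C(=O)O)c(=O)c2cc(F)c(N3CCN(C(=N)NS(=O)(=O)c4ccccc4C(F)(F)F)CC3)cc21` gives 43 nM. Compound 3 therefore has no measured gap to either of the other two at the digits reported.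

Compound 4 `CCn1cc(C(=O)O)c(=O)c2cc(F)c(N3CCN(C(=N)NS(=O)(=O)c4ccc(Cl)cc4)CC3)cc21` has not yet been measured in this assay. It differs from compound 3 in one place: 4-chlorophenyl in place of 2-(trifluoromethyl)phenyl on a sulfonyl sulfur. In words, 4-chlorophenyl takes the place of 2-(trifluoromethyl)phenyl on a sulfonyl sulfur.

Among the compounds with values here, only one measured step falls at this place, no change at the digits printed from compound 1 to compound 3 (within the scatter), and it stays within the scatter. It exchanges one trifluoromethyl-bearing phenyl group for another, so it does not test chlorine directly. Compound 2 does carry 4-chlorophenyl on a sulfonyl sulfur, and it gives 43 nM. Within the data shown here, no measured pair isolates the exact exchange planned here, so the expectation rests on this indirect evidence alone. With compound 3 at 43 nM as the starting point, the size expected is none beyond the scatter, and no direction is favoured: no change at the digits printed from compound 3 to compound 4 (within the scatter). For compound 4 the estimated value is 43 nM, with an expected range of 20 nM to 90 nM.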

Compound 4, half-maximal inhibitory concentration: 43 nM
Beside the measured number, compound 4's estimate shows no gap at the digits printed, and the stated range covers the measured number.
By their numbers in this assay, from the lowest: compounds 1, 2, 3 and 4 (each within the scatter of the next).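

In this assay, the change on the sulfonyl sulfur now has a direct test with chlorine: replacing 2-(trifluoromethyl)phenyl with 4-chlorophenyl gives no change at the digits printed from compound 3 to compound 4 (within the scatter), and replacing trifluoromethyl with chloro on an aromatic carbon gives no change at the digits printed from compound 1 to compound 4 (within the scatter). With 4-chlorophenyl held on the sulfonyl sulfur, a second place can also be read, as ethyl in place of cyclopropyl on an aromatic nitrogen gives no change at the digits printed from compound 2 to compound 4 (within the scatter). No measured evidence is available to explain why these exchanges leave the values level.

None of the exchanges shown moves the value beyond the scatter, so these compounds do not reveal which groups at either place, if any, would separate from the rest. On these data alone, it remains open whether a methoxy or amino group on the phenyl ring attached to the sulfonyl sulfur, or a longer chain such as propyl or butyl on the aromatic nitrogen, would stay level with these compounds.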